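Removing tert-butoxycarbonyl from compound 2: what to expect

The compounds below may be only part of what the source reports. "The series", "measured", "known", "first", "only" and "open" are said of these compounds alone.

Compound 1 `Cc1c(C)c2c(c(C)c1OC(=O)CCC(=O)O)CCC(C)(COc1ccc(CC3SC(=O)NC3=O)cc1)O2` reached only a limit in a functional assay on MCF7 cells (Homo sapiens) for antiproliferative activity, read by luminescence, with a stated time of 24 h (a lower number here means a stronger inhibitor, a higher number a weaker inhibitor), with > 50000 nM as its entry, not a number. Compound 2 `Cc1c(C)c2c(c(C)c1OC(=O)CCCCCCCNC(=O)OC(C)(C)C)CCC(C)(COc1ccc(/C=C3\SC(=O)NC3=O)cc1)O2` gives 13000 nM there and compound 3 `Cc1c(C)c2c(c(C)c1OC(=O)CCCCCCCNC(=O)CCCC[C@@H]1SC[C@@H]3NC(=O)N[C@@H]31)CCC(C)(COc1ccc(/C=C3\SC(=O)NC3=O)cc1)O2` gives 26000 nM there. These two values lie within the scatter of each other, so compound 2 stands level with compound 3, and both carry measured numbers where compound 1 has only its limit.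

Compound 4 `Cc1c(C)c2c(c(C)c1OC(=O)CCCCCCCN)CCC(C)(COc1ccc(/C=C3\SC(=O)NC3=O)cc1)O2` has not yet been measured. It departs from compound 2 at a single place: hydrogen in place of tert-butoxycarbonyl on an amine nitrogen is the whole change. For the measured compounds named here, no step between measured compounds shows what such a change does, so the expectation rests on little. Going by the values given here, with compound 2 at 13000 nM and compound 3 at 26000 nM as the only numbers, a large shift is not expected. In this assay the expected change is a 1.3-fold lower number from compound 2 to compound 4 (0.11 log units; within the scatter) as an estimate, within the scatter and leaning slightly towards a stronger inhibitor. Compound 4 is estimated at 10000 nM with an expected range from 4000 nM to 28000 nM once it is measured.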

Compound 4, half-maximal inhibitory concentration: 3200 nM
Compound 4: middle estimate off by 3.1-fold (0.49 log units), on the high side; measured number below the stated range.
By their numbers in this assay, from the lowest: compound 4; then compounds 2 and 3 (each within the scatter of the next). At a limit, above all of these: compound 1.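

The step at this position shows that what sits on the chain's terminal nitrogen matters in this assay: hydrogen in place of tert-butoxycarbonyl on an amine nitrogen gives a 4.1-fold lower number from compound 2 to compound 4 (0.61 log units; beyond the scatter). The earlier compounds shown here did not show this: compound 2 and compound 3, which both carry a group on that nitrogen, lie within the scatter of each other, whereas the free amine of compound 4 stands clearly apart from compound 2. Compound 1 remains at a limit and not a number, and it offers no measure of the change: the limit of > 50000 nM in this assay, at which 1 of the 4 values shown sits.

The compounds shown leave open whether a small group on this nitrogen, such as acetyl, would keep the lower number, and whether a shorter or longer chain ending in the same amine would lower it further or lose it. They also leave open whether a carboxylic acid at the chain end would behave like the amine, whether the step carries over to another cell line, and what lies behind it, which a single step cannot tell.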